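Chloro removal on the pendant phenyl of compound 3

The source may hold more compounds than are shown below. What is called first, only, known or untested is meant among the compounds shown, and "the series" means these compounds.

Among the three numbers so far in a functional assay on BGC-823 cells (Homo sapiens) for inhibition, read by CCK-8 assay, with a stated time of 48 h (a higher number here means a weaker inhibitor, a lower number a stronger inhibitor), compound 3 `Clc1ccc(C2=NN(C3=NC(c4ccccc4)CS3)C(c3cccc4ccccc34)C2)cc1` gives 19600 nM, and the other two lie within the scatter of it. Compound 1 `Clc1ccc(C2=NN(C3=NC(c4ccccc4)CS3)C(c3ccc4ccccc4c3)C2)cc1` gives 14600 nM and compound 2 `O=C1CSC(N2N=C(c3ccc(Cl)cc3)CC2c2cccc3ccccc23)=N1` gives 16400 nM; the measured steps, a 1.3-fold higher number from compound 1 to compound 3 (0.13 log units; within the scatter) and a 1.2-fold higher number from compound 2 to compound 3 (0.08 log units; within the scatter), both fall within the scatter, so these data do not separate the three compounds.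

Compound 4 `c1ccc(C2=NN(C3=NC(c4ccccc4)CS3)C(c3cccc4ccccc34)C2)cc1` differs from compound 3 in one place: hydrogen in place of chloro on an aromatic carbon. Cut one bond further out, the difference reads 4-chlorophenyl to phenyl. Neither measured step touches this part of the molecule; one exchanges naphthalen-1-yl for naphthalen-2-yl on a saturated ring carbon, the other exchanges the group on the ring amine nitrogen, and both stayed within the scatter. Among the measured compounds shown here, no measured step bears directly on the chloro, and nothing so far points to a shift beyond the scatter in this assay.

The estimate for compound 4 is 25000 nM, expected within 9000 nM to 70000 nM, which means an expected step of a 1.3-fold higher number from compound 3 to compound 4 (0.11 log units; within the scatter) that stays inside the scatter. Given the weak numbers across the series, compound 4 may also come back as a limit rather than a number.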

Compound 4, half-maximal inhibitory concentration: 14300 nM
The estimate for compound 4 lay 1.7-fold (0.24 log units) above the measured number; the measured number falls inside the stated range.
By their numbers in this assay, from the lowest: compounds 4, 1, 2 and 3 (each within the scatter of the next).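

Among the compounds shown here, at this position, on an aromatic carbon para to a large group, the chloro of compound 3 can give way to hydrogen without separating the two compounds in this assay: the change gives a 1.4-fold lower number from compound 3 to compound 4 (0.14 log units; within the scatter) and is the first measured step on the pendant phenyl. Read as 4-chlorophenyl to phenyl, it joins the exchange of naphthalen-1-yl for naphthalen-2-yl and the exchange of the group on the ring amine nitrogen as a third single-place change that stays within the scatter. No measurement here offers an explanation for this result.

Open, on these data alone, is whether an amine, a methoxy group or a carboxylic acid on this aromatic carbon would give a step beyond the scatter. Also open, as far as these compounds go, is whether hydrogen in place of chloro reads the same way in compound 1, which carries naphthalen-2-yl.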